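The source may report more compounds than this note shows. Statements on the series, on what has been measured and on what is new or still open speak of the compounds shown alone.

Compound 3, `CN1CCC(NS(=O)(=O)c2ccccc2Nc2cc(-c3ccc4ccn(C)c4c3)c3nccnc3c2)C1`, gives 3160 nM in an assay on lysate for inhibition of 6-phosphofructo-2-kinase/fructose-2,6-bisphosphatase 3 (Homo sapiens), with stated times of 0.5 min and 45 min; on this read-out lower numbers stand for stronger inhibition and higher numbers for weaker inhibition. Of the two numbers in hand it holds the lower: compound 1, `Cn1ccc2ccc(-c3cc(Nc4ccccc4S(N)(=O)=O)cc4nccnc34)cc21`, gives 37600 nM in this assay, and the two are separated by a 12-fold lower number from compound 1 to compound 3 (1.08 log units; beyond the scatter). Compound 2, `CNS(=O)(=O)c1ccccc1Nc1cc(-c2ccc3ccn(C)c3c2)c2nccnc2c1`, returns > 100000 nM in this assay, which is a limit of the assay rather than a number (the limit of > 100000 nM in this assay, at which 1 of the 3 values shown sits). The three share one core and differ only in what sits on the sulfonamide nitrogen: hydrogen in compound 1, methyl in compound 2, 1-methylpyrrolidin-3-yl in compound 3. Within that series the step of an at least 2.6-fold higher number from compound 1 to compound 2 (0.42 log units; beyond the scatter) went the wrong way, while an at least 31-fold lower number from compound 2 to compound 3 (1.50 log units; beyond the scatter) went strongly the right way.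

Compound 4, `Cn1cc(CNS(=O)(=O)c2ccccc2Nc2cc(-c3ccc4ccn(C)c4c3)c3nccnc3c2)cn1`, follows by the change ((1-methyl-1H-pyrazol-4-yl)methyl in place of 1-methylpyrrolidin-3-yl on a sulfonamide nitrogen). Among the compounds with values here, both of the measured steps onto the pyrrolidinyl group were large and favourable, and both show that hydrogen and methyl on that nitrogen give weak inhibition, so the entering group of seven heavy atoms is expected to land nearer compound 3 than compound 1, though no measured step speaks for the aromatic ring itself. Compound 4 is therefore estimated at 8000 nM in this assay, within 2500 nM to 30000 nM, which corresponds to an expected step of a 2.5-fold higher number from compound 3 to compound 4 (0.40 log units; beyond the scatter).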

Compound 4, half-maximal inhibitory concentration: > 100000 nM
Compound 4 gave a limit, no number; the forecaster's own chance of this, stated with the estimate: 5%; middle value at least 12-fold (1.09 log units) away from the limit.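

In this assay, within the data shown here, the earlier compounds could be read as saying that a larger group on a sulfonamide nitrogen improves on hydrogen or methyl, but replacing 1-methylpyrrolidin-3-yl with (1-methyl-1H-pyrazol-4-yl)methyl rules that reading out, with an at least 31-fold higher number from compound 3 to compound 4 (1.50 log units; beyond the scatter). Measured against the unsubstituted sulfonamide, the new group brings no gain either, with an at least 2.6-fold higher number from compound 1 to compound 4 (0.42 log units; beyond the scatter), so among the four compounds only 1-methylpyrrolidin-3-yl improves on hydrogen at this position. Compound 4 gives a limit rather than a number and shares it with compound 2, so the step between those two cannot be read: the limit of > 100000 nM in this assay, at which 2 of the 4 values shown sit.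

This change swaps the non-aromatic ring for an aromatic one and also adds a chain carbon, and the compounds shown do not separate these two differences. On these data alone, it remains open whether a (1-methylpyrrolidin-3-yl)methyl group, which keeps the saturated ring with the added carbon, or a cyclopentyl group, which has no ring nitrogen, would stay close to compound 3 at 3160 nM.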